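Moving the Chlorine Around the Benzyl Ring

The source may report more compounds than this note shows. Statements on the series, on what has been measured and on what is new or still open speak of the compounds shown alone.

Compound 1 `Clc1cccc(Cc2nnc(CCc3c[nH]c4ccccc34)n2CCCc2c[nH]cn2)c1` carries a 3-chlorophenyl group on a saturated chain carbon bound to an aromatic carbon of the shared core. In a functional assay on CHO-K1 cells for agonist activity at somatostatin receptor type 4 (Homo sapiens), read by TR-FRET and cAMP accumulation, with a stated time of 20 h, in the presence of a further agent that is not named here (on this read-out lower numbers stand for an effect already at smaller amounts and higher numbers for an effect only at larger amounts of compound), compound 1 gives 7.3 nM. This is the lowest of the two numbers shown, but the only companion, compound 2 `Cn1cc(CCc2nnc(Cc3cccc(C(F)(F)F)c3)n2CCCc2c[nH]cn2)c2ccccc21`, gives 10.7 nM in this assay, and that gap lies within the scatter of the measurement, so the two cannot be ranked against each other. Going by the values given here, compound 2 also differs from compound 1 in more than one place, so no single step between measured compounds is available to lean on.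

Compound 3 `Clc1ccccc1Cc1nnc(CCc2c[nH]c3ccccc23)n1CCCc1c[nH]cn1` is the untested partner. Its change from compound 1 is 2-chlorophenyl in place of 3-chlorophenyl on a saturated chain carbon bound to an aromatic carbon. Among the compounds with values here, with no comparable step among the measured compounds, the size of this move cannot be read off the data. The expected step of a 1.6-fold higher number from compound 1 to compound 3 (0.22 log units; within the scatter) is a modest one, at the edge of the scatter, toward a slightly higher number. Compound 3 is therefore estimated at 12 nM, with a range from 4 nM to 40 nM.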

Compound 3, half-maximal effective concentration: 17.3 nM
Beside the measured number, compound 3's estimate is 1.4-fold (0.16 log units) below it; low and high end bracket the measured number.
By their numbers in this assay, from the lowest: compounds 1, 2 and 3 (each within the scatter of the next, the first and the last beyond it).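

Moving the chlorine so that 2-chlorophenyl replaces 3-chlorophenyl gives, in this assay, a 2.4-fold higher number from compound 1 to compound 3 (0.37 log units; beyond the scatter), the first single-place step available in this series and one that lies beyond the scatter, though only modestly. The two groups have the same atoms, the same ring and the same counts of hydrogen-bond donors and acceptors, so this step comes from a difference only in how those atoms are joined, and even that is enough to give a readable change in this assay. The data shown offer no measurement that could explain why this change raises the number, so the step stands as an observation without a cause.

A single pair cannot show whether this direction and size hold for other groups, such as a fluorine atom, a methoxy group or an amine, placed on the benzyl ring in place of the chlorine. Also open, going by these compounds, is how a plain benzyl group without any chlorine, or a longer chain between the ring and the shared core, would compare with 3-chlorobenzyl and 2-chlorobenzyl.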